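This account rests on a few compounds, and the source may have more. Where it says the series, first, only, none or still open, it means among the compounds named here.

Of the compounds shown here, three sharing one core have been measured in a functional assay on MCF7 cells (Homo sapiens) for antiproliferative activity, read by MTT assay, with a stated time of 72 h; a higher number here means a weaker inhibitor, a lower number a stronger inhibitor. Compound 1 (`C/C(=N\NC(=O)c1cccc(S(=O)(=O)N2CCOCC2)c1)c1ccc(F)cc1`) gives > 100000 nM, which is a limit of the assay and not a number. Compound 3 (`O=C(N/N=C/c1ccco1)c1cccc(S(=O)(=O)N2CCOCC2)c1`) gives > 100000 nM, again a limit and not a number. Compound 3 thus has no number of its own, and its place is the limit of > 100000 nM in this assay, at which 2 of the 3 values shown sit. Compound 2 (`C/C(=N\NC(=O)c1cccc(S(=O)(=O)N2CCOCC2)c1)c1cccc(N)c1O`), by contrast, gives a measured 1010 nM.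

The change now in question leads to compound 4 (`O=C(N/N=C/c1cc(Cl)ccc1O)c1cccc(S(=O)(=O)N2CCOCC2)c1`), with 5-chloro-2-hydroxyphenyl in place of furan-2-yl on a carbon with a double bond to nitrogen.

Among the compounds with values here, one measured step bears on this change. With 3-amino-2-hydroxyphenyl in place of 4-fluorophenyl at that same carbon, the data show an at least 99-fold lower number from compound 1 to compound 2 (1.99 log units; beyond the scatter), a large step beyond the scatter. Compound 4 also brings in a hydroxyphenyl group, so a large step toward a lower number is expected in this assay. This rests on a single pair, however, and compound 4 carries chloro rather than amino, so the expectation is loose. The expected step is an at least 33-fold lower number from compound 3 to compound 4 (1.52 log units; beyond the scatter). Compound 4 is estimated at 3000 nM, with an expected range from 500 nM to 30000 nM.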

Compound 4, half-maximal inhibitory concentration: 16500 nM
Compound 4: middle estimate off by 5.5-fold (0.74 log units), on the low side; the measured number falls inside the stated range.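

At the carbon with a double bond to nitrogen, a second pair now moves in the same direction as the first: in this assay, 5-chloro-2-hydroxyphenyl in place of furan-2-yl gives an at least 6.0-fold lower number from compound 3 to compound 4 (0.78 log units; beyond the scatter). Both listed steps bring in a 2-hydroxyphenyl-type ring, and none of the compounds shown goes against this, while this second pair shows that a number can be reached with chloro on that ring and no amino group. The true size of the new step remains unknown, because compound 3 has only a limit of the assay and no number of its own: the limit of > 100000 nM in this assay, at which 2 of the 4 values shown sit.

The compounds shown leave open whether the hydroxy group, the chloro group or the larger six-membered ring carries the step, and a plain phenyl, a 2-hydroxyphenyl and a 2-methoxyphenyl group at this carbon would begin to separate these. They also leave open how far the step depends on the rest of the shared core, as each of the two pairs starts from a different ring and neither pair has a measured number at its starting compound.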